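A few compounds are considered here, and "the series" means these few. Any claim that something is new, unique, unknown or untested is made for them only; others in the source may bear on it.

Compound 1, with the structure `CCOC(=O)CN(C)CC#Cc1cc2ncnc(Nc3ccc(OCc4cccc(F)c4)c(Cl)c3)c2s1`, is the starting point. In an ADME assay on HepG2 cells (Homo sapiens) for cytotoxicity (a lower number here means that less compound is tolerated, a higher number that more compound is tolerated), compound 1 gives 26 uM. Compound 2, with the structure `Fc1cccc(COc2ccc(Nc3ncnc4cc(C#CC5CCCC5)sc34)cc2Cl)c1`, carries cyclopentyl in place of (((ethoxycarbonyl)methyl)(methyl)amino)methyl on a triple-bonded carbon. For compound 2 this assay reports only a limit, > 31 uM, at which the measurement stops rather than a number. The resulting step is an at least 1.1-fold higher number from compound 1 to compound 2 (0.07 log units; that floor lies within the scatter), and it rests on (the limit of > 31 uM in this assay, at which 1 of the 3 values shown sits).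

Compound 3 has the structure `CCOC(=O)CN(C)CC#Cc1ccc2ncnc(Nc3ccc(OCc4cccc(F)c4)c(Cl)c3)c2c1` and shares the side group of compound 1 on a different core; the difference between the two cores is not broken down here. For compound 3 this assay again reports only a limit, > 28 uM. This is the limit of > 28 uM in this assay, at which 1 of the 3 values shown sits.

Compound 4, with the structure `Fc1cccc(COc2ccc(Nc3ncnc4ccc(C#CC5CCCC5)cc34)cc2Cl)c1`, has not yet been measured. It stands to compound 3 as compound 2 stands to compound 1, carrying the same change, (cyclopentyl in place of (((ethoxycarbonyl)methyl)(methyl)amino)methyl on a triple-bonded carbon). The step from compound 3 to compound 4 is expected to be a step that the limit leaves unreadable from compound 3 to compound 4, about the size seen in the earlier pair, because that earlier pair gave an at least 1.1-fold higher number from compound 1 to compound 2 (0.07 log units; that floor lies within the scatter) and its second member already sat at a limit. Compound 4 is therefore expected to show 35 uM in this assay, most likely again reported as a limit rather than a number, between 20 uM and 80 uM.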

Compound 4, half-maximal toxic concentration: > 3 uM
Compound 4 was reported as a limit; the forecaster's own chance of this, stated with the estimate: 70%; the middle value does not contradict the limit.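

In this assay compound 4 gives only a limit, > 3 uM. Among these compounds, compound 3 likewise gives only a limit, > 28 uM, so no step from compound 3 to compound 4 can be read. The compounds shown leave open whether cyclopentyl in place of (((ethoxycarbonyl)methyl)(methyl)amino)methyl on the core of compound 3 changes how much compound the cells tolerate, and in which direction.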